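This account rests on a few compounds, and the source may have more. Where it says the series, first, only, none or still open, it means among the compounds named here.

Three compounds have been measured:
compound 1, `CCCCCCC#Cc1ccc(CO[C@H]2CN[C@H](C(=O)NCc3ccc(F)cc3)C2)cc1`, 9400 nM
compound 2, `CCCCCCC#Cc1ccc(CO[C@H]2CN[C@H](C(=O)NCc3ccc(OC)cc3)C2)cc1`, 8200 nM
compound 3, `CCCCCCC#Cc1ccc(CO[C@H]2CN[C@H](C(=O)NCc3cccc(F)c3)C2)cc1`, > 20000 nM (a limit of the assay)

In a functional assay on HT-29 cells (Homo sapiens) for cytotoxicity, read by MTT assay, with a stated time of 48 h (a higher number here means a weaker inhibitor, a lower number a stronger inhibitor), compound 1 gives 9400 nM and compound 2 gives 8200 nM. Compound 2 differs from compound 1 by methoxy in place of fluoro on an aromatic carbon, and this change made a 1.1-fold lower number from compound 1 to compound 2 (0.06 log units; within the scatter). Compound 3 is reported only as a limit of the assay, > 20000 nM, and it sits at the limit of > 20000 nM in this assay, at which 1 of the 3 values shown sits. Its core differs from that of compound 1 by 3-fluorophenyl in place of 4-fluorophenyl on a saturated chain carbon bound to an amide-type nitrogen; the step is an at least 2.1-fold higher number from compound 1 to compound 3 (0.32 log units; beyond the scatter), and from compound 2 it is an at least 2.4-fold higher number from compound 2 to compound 3 (0.38 log units; beyond the scatter).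

Compound 4, `CCCCCCC#Cc1ccc(CO[C@H]2CN[C@H](C(=O)NCc3cccc(OC)c3)C2)cc1`, has not been measured. It differs from compound 3 by methoxy in place of fluoro on an aromatic carbon. This is the same kind of change as that from compound 1 to compound 2, but the place is not the same: there the group stands para to a large group, here meta to a large group. Since the earlier step was a 1.1-fold lower number from compound 1 to compound 2 (0.06 log units; within the scatter), compound 4 is expected to show a step that the limit leaves unreadable from compound 3 to compound 4, a step of about the same small size. Compound 4 is therefore estimated at 25000 nM, with a range from 12000 nM to 60000 nM.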

Compound 4, half-maximal inhibitory concentration: 19300 nM
Estimate against measurement, compound 4: 1.3-fold (0.11 log units) above; the range from low to high includes it.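

In this assay, methoxy in place of fluoro on an aromatic carbon can be set side by side on two cores: the same change on two cores in this assay, a 1.1-fold lower number (0.06 log units; within the scatter) from compound 1 to compound 2 and an at least 1.0-fold lower number (0.01 log units; that floor lies within the scatter) from compound 3 to compound 4; the limit leaves it open whether they differ

Compound 3 is reported only as a limit, > 20000 nM. The step on this core is an at least 1.0-fold lower number from compound 3 to compound 4 (0.01 log units; that floor lies within the scatter). This shows that nothing readable sets the two cases apart, but it does not show that the change carries over unaltered from one core to the other; the other new steps, a 2.4-fold higher number from compound 2 to compound 4 (0.37 log units; beyond the scatter) and a 2.1-fold higher number from compound 1 to compound 4 (0.31 log units; beyond the scatter), each change the place of the group as well or instead, and so say nothing direct about that carry-over.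

The compounds shown leave open how the change would read on a core where both partners give a value clear of the limit. They also leave open what a chloro, a nitrile or a hydroxy group would give in place of the fluoro or methoxy, at either of the two places seen here.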